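Mirror-image cyclohexyl amides and thermodynamic solubility

The source may report more compounds than this note shows. Statements on the series, on what has been measured and on what is new or still open speak of the compounds shown alone.

Compound 1 `C[C@H]1CCCC[C@H]1NC(=O)c1cc2c(Cl)cc(Cl)cc2[nH]1`: < 4000 nM
Compound 2 `CC1CCC(NC(=O)c2cc3c(Cl)cc(Cl)cc3[nH]2)CC1`: < 4000 nM
Compound 3 `C[C@H]1CC[C@@H](NC(=O)c2cc3c(Cl)cc(Cl)cc3[nH]2)CC1`: < 4000 nM

In a physicochemical assay for solubility, measured as thermodynamic solubility, with a stated time of 24 h, at pH 6.8 (on this read-out higher numbers stand for higher solubility and lower numbers for lower solubility), compound 1 gives < 4000 nM, which is a limit of the assay and not a number. Compound 2 likewise gives < 4000 nM, again a limit. Compound 3 gives < 4000 nM, also a limit, so its standing among the three is known only as a limit shared with both companions. The steps a step that the two limits leave unreadable from compound 1 to compound 2 and a step that the two limits leave unreadable from compound 1 to compound 3 cannot be read, and the same holds for a step that the two limits leave unreadable from compound 2 to compound 3, because the limit of < 4000 nM in this assay, at which 3 of the 3 values shown sit, leaves no number to compare; the fact that one of compounds 2 and 3 is drawn with a defined configuration and the other without, at the place where they differ adds no readable information either.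

Compound 4 `C[C@H]1CC[C@H](NC(=O)c2cc3c(Cl)cc(Cl)cc3[nH]2)CC1` is the mirror image of compound 3: the two compounds have the same atoms and bonds and differ only in configuration as drawn: 2 of 2 stereo elements differ (all stereocentres are inverted: mirror images); a stereocentre at a saturated ring carbon is drawn s in compound 3 and r in compound 4; a stereocentre at a saturated ring carbon is drawn s in compound 3 and r in compound 4. Among the measured compounds shown here, no measured step bears on this change in a readable way, since every step among compounds 1, 2 and 3 is unreadable. The expectation for the step from compound 3 to compound 4 in this assay is therefore a step that the limit leaves unreadable from compound 3 to compound 4, in no direction beyond the scatter. Compound 4 is expected to give about 2000 nM, in the range 500 nM to 4000 nM, most likely reported again as a limit.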

Compound 4, solubility: < 4000 nM
Compound 4 ended at the assay's limit; the forecaster's own chance of this, stated with the estimate: 80%; the middle value lies beyond the limit too.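

In this assay compound 4 gives < 4000 nM, which is a limit of the assay and not a number. Among the compounds shown here, no step joining compound 4 to compound 1, compound 2 or compound 3 can be read, because no number is left to compare: the limit of < 4000 nM in this assay, at which 4 of the 4 values shown sit. The compounds shown leave open whether inverting both stereocentres changes solubility at all.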